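From 3-(hydroxymethyl)phenyl to 2-fluorophenyl on the shared core

The compounds below may be only part of what the source reports. "The series", "measured", "known", "first", "only" and "open" are said of these compounds alone.

In an ADME assay on HepG2 cells (Homo sapiens) for cytotoxicity, read by MTT assay, with a stated time of 72 h (a higher number here means that more compound is tolerated, a lower number that less compound is tolerated), compound 2 `O=[N+]([O-])c1c(CS(=O)(=O)c2ccccc2)nc2c(-c3cccc(CO)c3)cc(Cl)cn12` gives > 25000 nM as a limit and not a number. Compound 1 `COc1ccc(-c2cc(Cl)cn3c([N+](=O)[O-])c(CS(=O)(=O)c4ccccc4)nc23)cc1` gives > 3900 nM and this too is a limit. Among the compounds with values here, the only measured step that the two limits leave unreadable from compound 1 to compound 2 therefore has no readable size. The change to compound 3 `O=[N+]([O-])c1c(CS(=O)(=O)c2ccccc2)nc2c(-c3ccccc3F)cc(Cl)cn12` is 2-fluorophenyl in place of 3-(hydroxymethyl)phenyl on an aromatic carbon. Within the data shown here, with no step of known size to lean on, nothing beyond the scatter is expected in this assay and a number no higher from compound 2 to compound 3 (the limit leaves the size open) is the estimated step. For compound 3 the estimate is 25000 nM with an expected range from 8000 nM to 80000 nM in this measurement.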

Compound 3, half-maximal cytotoxic concentration: > 3900 nM
Compound 3: no number, only a limit (the forecaster's own chance of this, stated with the estimate: 65%); the middle value is on the limit's open side.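

Within the data shown here, compound 1, compound 2 and compound 3 all give only limits, so no step from compound 3 to either of the others can be read. The compounds shown leave open whether swapping these aromatic groups changes how much compound is tolerated.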